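An Acetyl Oxime Ester in Place of a Fluoroethyl Ether

This account rests on a few compounds, and the source may have more. Where it says the series, first, only, none or still open, it means among the compounds named here.

Measured so far:
compound 1 `OC1O[C@H](CO/N=C2\CCc3cc(Sc4cc(F)cc(C5CCOCC5)c4)ccc32)[C@H](O)[C@H](O)[C@H]1O` — > 2500 nM
compound 2 `C/C(=N\OCCF)c1ccc(Sc2cc(F)cc(C3CCOCC3)c2)cc1` — 40 nM
compound 3 `CO[C@]1(c2cc(F)cc(S(=O)(=O)c3ccc(/C(C)=N/O)cc3)c2)CCO[C@@H](C)C1` — 20 nM

In a functional assay (blood) for inhibition, with Homo sapiens as the target (a higher number here means a weaker inhibitor, a lower number a stronger inhibitor), compound 2 gives 40 nM, the higher of the two numbers shown. Compound 3 gives 20 nM, which lies within the usual scatter of the number for compound 2, so no order between these two can be read. Compound 1 sits at the limit of > 2500 nM in this assay, at which 1 of the 3 values shown sits; its result is a limit of the assay and not a number.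

The step followed here runs from compound 2 to compound 4 `CC(=O)O/N=C(\C)c1ccc(Sc2cc(F)cc(C3CCOCC3)c2)cc1`, which has not yet been measured in this assay. The change is acetyl in place of 2-fluoroethyl on an oxygen. No step between measured compounds that differ in one place is available, so the size of an exchange on that oxygen has no precedent among these three. For compound 4 a modest loss is expected, with the step of a 2.3-fold higher number from compound 2 to compound 4 (0.35 log units; beyond the scatter) lying a little beyond the scatter. Compound 4 is therefore estimated at 90 nM, with a range from 25 nM to 350 nM.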

Compound 4, half-maximal inhibitory concentration: 50 nM
Compound 4: the middle estimate sits 1.8-fold (0.26 log units) above what was measured, and the stated range covers the measured number.
By their numbers in this assay, from the lowest: compounds 3, 2 and 4 (each within the scatter of the next, the first and the last beyond it). At a limit, above all of these: compound 1.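

In this assay, for the compounds shown here, the exchange on the oxygen whose other neighbour is the double-bonded nitrogen gives the first reading of a single change, a 1.3-fold higher number from compound 2 to compound 4 (0.10 log units; within the scatter) and so no order can be read between these two compounds. At this position, then, acetyl with its hydrogen-bond acceptor and 2-fluoroethyl with none leave the number within the scatter of each other, although one brings a carbonyl and the other a fluorine. Nothing at hand gives a cause for this result.

On these data alone, it remains open whether a longer chain, a carboxylic acid or an amine on this oxygen would also leave the number unmoved. As far as these compounds go, it is equally open whether acetyl in place of 2-fluoroethyl would read the same way on a different core.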